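Phenyl for piperidinylmethyl on the anilino nitrogen of compound 2

This account rests on a few compounds, and the source may have more. Where it says the series, first, only, none or still open, it means among the compounds named here.

In an assay on isolated protein for inhibition of tyrosine-protein kinase receptor UFO (Homo sapiens), with a stated time of 1.5 h (on this read-out lower numbers stand for stronger inhibition and higher numbers for weaker inhibition), three compounds have been measured. Compound 1 `Cc1cnc2[nH]ccc2c1Cl` gives 20200 nM, compound 3 `CN1CC[C@@H](Nc2cc3c(-c4cnn(C)c4)n[nH]c3cc2Cl)C1` gives 74000 nM, and compound 2 `CN1CCC(CNc2ccc3[nH]nc(-c4cnn(C)c4)c3c2)CC1` gives 1850000 nM, the highest of the three numbers, far beyond the scatter from either of the others. Compound 4 `Cn1cc(-c2n[nH]c3ccc(Nc4ccccc4)cc23)cn1` is not yet measured; it differs from compound 2 in one place: phenyl in place of (1-methylpiperidin-4-yl)methyl on a nitrogen on an aromatic ring. For the measured compounds named here, no pair of measured compounds shows a comparable change, so the expectation for compound 4 rests on compound 2 alone. The step from compound 2 to compound 4 is expected to be a modest fall, a 3.7-fold lower number from compound 2 to compound 4 (0.57 log units; beyond the scatter), though it might also stay within the scatter. Compound 4 is accordingly estimated at 500000 nM, with a range from 100000 nM to 2500000 nM.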

Compound 4, half-maximal inhibitory concentration: 580 nM
Beside the measured number, compound 4's estimate is 860-fold (2.94 log units) above it; measured number outside the range, below it.
By their numbers in this assay, from the lowest: compound 4; then compound 1; then compound 3; then compound 2.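

For the compounds shown here, at the nitrogen on an aromatic ring, the group carried there has a very large effect in this assay: phenyl in place of (1-methylpiperidin-4-yl)methyl gives a 3200-fold lower number from compound 2 to compound 4 (3.50 log units; beyond the scatter) and is the first matched change. The step replaces a six-membered non-aromatic ring bearing one hetero atom with an aromatic ring of carbon only. Nothing given here accounts for its size. On these data alone, whether the step follows from the aromatic ring or from losing the ring nitrogen remains open. Cyclohexylmethyl or benzyl on the same nitrogen would help separate these two readings.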